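A hydroxy group added to the phenyl of compound 1

This account rests on a few compounds, and the source may have more. Where it says the series, first, only, none or still open, it means among the compounds named here.

Compound 1 `CCOC(=O)N1N=C(c2ccccc2)CC1c1cc(OC)c(OC)c(OC)c1`: 5610 nM
Compound 2 `CCCOC(=O)N1N=C(c2ccccc2)CC1c1cc(OC)c(OC)c(OC)c1`: 14400 nM

Among the measured compounds shown here, in a functional assay on MDA-MB-231 cells (Homo sapiens) for antiproliferative activity, read by MTT assay, with a stated time of 48 h (a lower number here means a stronger inhibitor of growth, a higher number a weaker inhibitor of growth), compound 1 gives the lower of the two numbers so far, 5610 nM. Compound 3 `CCOC(=O)N1N=C(c2cccc(O)c2)CC1c1cc(OC)c(OC)c(OC)c1` keeps the core of compound 1 and differs in one place: hydroxy in place of hydrogen on an aromatic carbon. This is hydroxy in place of hydrogen on an aromatic carbon, turning phenyl into 3-hydroxyphenyl. For the measured compounds named here, the only measured step is a 2.6-fold higher number from compound 1 to compound 2 (0.41 log units; beyond the scatter), and that change lies on a saturated chain, not on an aromatic ring. Going by the values given here, no measured step touches the place that changes here, so the data give no direction. That single step serves only as a rough guide to size: a shift of similar size in this assay is expected at most, either way, and possibly none beyond the scatter. The central expected step is a 1.1-fold lower number from compound 1 to compound 3 (0.05 log units; within the scatter). For compound 3 the estimated value is 5000 nM, with an expected range of 1700 nM to 15000 nM.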

Compound 3, concentration for 50% growth inhibition: 4710 nM
Compound 3: middle estimate off by 1.1-fold (0.03 log units), on the high side; low and high end bracket the measured number.
By their numbers in this assay, from the lowest: compounds 3 and 1 (each within the scatter of the next); then compound 2.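

In this assay, hydroxy in place of hydrogen on an aromatic carbon, turning phenyl into 3-hydroxyphenyl, gives a 1.2-fold lower number from compound 1 to compound 3 (0.08 log units; within the scatter). Among the compounds shown here, this is the first measured change on this aromatic ring, as the earlier step lay on a saturated chain, and it shows that at this place, meta to a large group, the added hydroxy leaves the number within the scatter of compound 1. The change therefore has no readable effect on growth inhibition in these cells, and nothing measured here offers an explanation for that result.

Going by these compounds, whether an amine, a carboxylic acid or a methoxy group on the same aromatic carbon would move the number beyond the scatter remains open. So does whether hydroxy would behave in the same way on another carbon of this ring, or alongside the longer chain of compound 2.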